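A few compounds are considered here, and "the series" means these few. Any claim that something is new, unique, unknown or untested is made for them only; others in the source may bear on it.

Values in a functional assay on HT-29 cells (Homo sapiens) for inhibition, read by sulforhodamine B assay, with a stated time of 48 h; a higher number here means a weaker inhibitor of growth, a lower number a stronger inhibitor of growth:
compound 1 `Cc1ccc(NC2=NCCO2)cc1`: 13000 nM
compound 2 `Cc1ccc(NC2=NCCO2)cc1C`: 2700 nM
compound 3 `Cc1ccc(NC(=O)NC(=O)CCl)cc1`: 10000 nM

Compound 1 and compound 2 share one core and differ by methyl in place of hydrogen on an aromatic carbon. That change gave a 4.8-fold lower number from compound 1 to compound 2 (0.68 log units; beyond the scatter) in this assay. Compound 3 carries a different core; how the core of compound 3 differs from the core of compound 1 is not broken down here. In this assay compound 3 and compound 1 give numbers that lie within the scatter of each other, while the number of compound 3 is higher than that of compound 2 by a margin beyond the scatter.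

Compound 4 `Cc1ccc(NC(=O)NC(=O)CCl)cc1C` is not yet measured. It stands to compound 3 as compound 2 stands to compound 1, by methyl in place of hydrogen on an aromatic carbon. The surroundings of the change are not identical: in compound 1 the entering methyl sits meta to a group of 6 heavy atoms, in compound 3 meta to a group of 8 heavy atoms, so this is the same kind of change rather than the same change. Within the data shown here, only the one earlier pair is available to judge it by, and the step of a 4.8-fold lower number from compound 1 to compound 2 (0.68 log units; beyond the scatter) is modest but beyond the scatter. On that basis the step from compound 3 to compound 4 in this assay is expected to be a 4.0-fold lower number from compound 3 to compound 4 (0.60 log units; beyond the scatter), similar in direction and roughly in size to the earlier one. For compound 4 in this assay the expected value is 2500 nM, with a likely range from 1000 nM to 8000 nM.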

Compound 4, concentration for 50% growth inhibition: 6900 nM
Compound 4: middle estimate off by 2.8-fold (0.44 log units), on the low side; measured number inside the range.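

In this assay the entering methyl gives a 1.4-fold lower number from compound 3 to compound 4 (0.16 log units; within the scatter) on the core of compound 3, a step that cannot be told from the scatter. Among these compounds, with only one pair on each core, this shows that the size of the step seen on the core of compound 1 cannot be assumed for the core of compound 3, but it does not show why the two cores differ or how the change would behave on a further core. The direction is lower on both cores, yet only the first step is beyond the scatter, and the two steps differ by more than the scatter of two such steps allows: the same change on two cores in this assay, a 4.8-fold lower number (0.68 log units; beyond the scatter) from compound 1 to compound 2 and a 1.4-fold lower number (0.16 log units; within the scatter) from compound 3 to compound 4, 3.3-fold (0.52 log units) apart, beyond the scatter of two such steps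

Still open, going by these compounds, is whether another group in the same place on the ring, such as ethyl, methoxy or chlorine, would follow the pattern of the core of compound 1 or that of compound 3. Also open, on these data alone, is how much of the number of compound 3 depends on the chloroacetyl end, which a plain acetyl or a longer chain in its place would help to settle.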